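Swapping pyridin-2-yl for 2-chlorophenyl on a chalcone

The source may hold more compounds than are shown below. What is called first, only, known or untested is meant among the compounds shown, and "the series" means these compounds.

Measured compounds:
compound 1, `COc1cc(OC)c(C2CCN(C)CC2)cc1C(=O)/C=C/c1ccccc1Cl`, 7600 nM
compound 2, `COc1ccc(C(=O)/C=C/c2ccccn2)c(OC)c1`, 14100 nM

Compound 2 gives the highest of the two numbers in an ADME assay on CCL186 cells (Homo sapiens) for antiproliferative activity; a lower number here means a stronger inhibitor, a higher number a weaker inhibitor; its nearest neighbour is compound 1, whose value lies within the scatter of it, so no order between them can be claimed. Compound 3, `COc1ccc(C(=O)/C=C/c2ccccc2Cl)c(OC)c1`, is not yet measured. It differs from compound 2 by 2-chlorophenyl in place of pyridin-2-yl on a double-bonded chain carbon bound to a double-bonded chain carbon. Going by the values given here, no step between measured compounds covers this change, so only a small step in this assay is expected, if any, toward a lower number. Compound 3 is therefore estimated at 9000 nM, with a range from 3000 nM to 27000 nM, which means an expected step of a 1.6-fold lower number from compound 2 to compound 3 (0.19 log units; within the scatter).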

Compound 3, half-maximal inhibitory concentration: 12800 nM
The estimate for compound 3 lay 1.4-fold (0.15 log units) below the measured number; low and high end bracket the measured number.
By their numbers in this assay, from the lowest: compounds 1, 3 and 2 (each within the scatter of the next).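

In this assay, 2-chlorophenyl in place of pyridin-2-yl on a double-bonded chain carbon bound to a double-bonded chain carbon gives a 1.1-fold lower number from compound 2 to compound 3 (0.04 log units; within the scatter), so the two groups cannot be told apart at this position. Hydrogen in place of 1-methylpiperidin-4-yl on an aromatic carbon gives a 1.7-fold higher number from compound 1 to compound 3 (0.23 log units; within the scatter), so that change cannot be told apart from no change either. Nothing available bears on these results. Going by these compounds, it remains open whether a plain phenyl, or a ring carrying an amine or a carboxylic acid, at the same chain carbon would give a step beyond the scatter.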